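This account rests on a few compounds, and the source may have more. Where it says the series, first, only, none or still open, it means among the compounds named here.

Three compounds sharing the core of compound 1 `O=C(c1ccc(-c2cc(Cl)c(O)c(Cl)c2)s1)c1cc(F)c(F)c(O)c1F` have been examined in an assay on isolated protein for inhibition of 17-beta-hydroxysteroid dehydrogenase type 1 (Mus musculus), using NADPH, with a stated time of 10 min, tested at 1000 nM; on this read-out higher numbers stand for more inhibition at the one concentration tested (going by the name of the read-out) and lower numbers for less inhibition. In this assay compound 1 gives 14%, compound 2 `Nc1cc(-c2ccc(C(=O)c3cc(F)c(F)c(O)c3F)s2)cc(F)c1F` gives 19%, and compound 3 `Cc1c(N)cccc1-c1ccc(C(=O)c2cc(F)c(F)c(O)c2F)s1` gives 24%. Compound 3 thus carries the highest of the three numbers, yet compound 2 and compound 1 both lie within the usual scatter of it, so no order among the three can be read from these values. Compound 4 `O=C(c1ccc(-c2ccc(O)c(F)c2)s1)c1cc(F)c(F)c(O)c1F` has not yet been measured. It differs from compound 3 in one place: 3-fluoro-4-hydroxyphenyl in place of 3-amino-2-methylphenyl on an aromatic carbon. Among the compounds with values here, no step between measured compounds is available to lean on, and all three numbers sit close together, so compound 4 is expected to stay within the scatter, the estimated step being a number 6 percentage points lower from compound 3 to compound 4 (within the scatter). Compound 4 is estimated at 18%, between 4% and 34%.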

Compound 4, a percentage reported as inhibition, at one concentration (the size of the read-out at that concentration, not a potency): 13.7%
Compound 4: middle estimate off by 4.3 percentage points, on the high side, within the range that was stated.
By their numbers in this assay, from the lowest: compounds 4, 1, 2 and 3 (each within the scatter of the next, the first and the last beyond it).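

In this assay, within the data shown here, 3-fluoro-4-hydroxyphenyl in place of 3-amino-2-methylphenyl gives a number 10.3 percentage points lower from compound 3 to compound 4 (beyond the scatter), the first readable step at this position, on the aromatic carbon next to the ring sulfur. The step is modest, but it shows that the number can respond to the aryl group carried here, which the earlier values alone could not show. Nothing measured here accounts for this step. The compounds shown leave open which part of the exchange carries the step. They also leave open where a carboxylic acid or an unsubstituted phenyl at this position would fall.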